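The source may report more compounds than this note shows. Statements on the series, on what has been measured and on what is new or still open speak of the compounds shown alone.

Of the compounds shown here, two are measured so far. Compound 1 `CC(C)c1onc(-c2c(Cl)cccc2Cl)c1COc1ccc(NC(=O)c2ccc(C(=O)O)cc2)c(C(F)(F)F)n1` gives 385 nM in a functional assay on HEK293 cells for agonist activity at Bile acid receptor (Homo sapiens), read by a luciferase reporter; on this read-out lower numbers stand for an effect already at smaller amounts and higher numbers for an effect only at larger amounts of compound. Going by the values given here, compound 2 `CC(C)c1onc(-c2c(Cl)cccc2Cl)c1COc1ccc(N(C)Cc2cccc(C(=O)O)c2)c(C(F)(F)F)n1` gives 6 nM in this assay, the lowest of the two numbers; the only other value, that of compound 1, lies a 64-fold lower number from compound 1 to compound 2 (1.81 log units; beyond the scatter) away, a change in which (3-carboxybenzyl)(methyl)amino replaced ((4-carboxyphenyl)carbonyl)amino on an aromatic carbon.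

Compound 3 `CC(C)c1onc(-c2c(Cl)cccc2Cl)c1COc1ccc(N(C)Cc2ccc(OCCO)cc2)c(C(F)(F)F)n1` is not yet measured. It differs from compound 2 in one place: 4-(2-hydroxyethoxy)phenyl in place of 3-carboxyphenyl on a saturated chain carbon bound to a nitrogen on an aromatic ring. Among the compounds with values here, both measured compounds carry a carboxylic acid on this part of the molecule, and no measured step tests what happens when that acid is exchanged for a hydroxyethoxy group, so the single step from compound 1 to compound 2 bears on it only indirectly. Without a guide of that kind, a higher number than that of compound 2 is expected for compound 3, a step of a 10-fold higher number from compound 2 to compound 3 (1.00 log units; beyond the scatter) in this assay. The estimate for compound 3 is therefore 60 nM, within a range from 8 nM to 500 nM.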

Compound 3, half-maximal effective concentration: 155 nM
Compound 3: the middle estimate sits 2.6-fold (0.41 log units) below what was measured; low and high end bracket the measured number.
By their numbers in this assay, from the lowest: compound 2; then compound 3; then compound 1.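

In this assay the exchange of 3-carboxyphenyl for 4-(2-hydroxyethoxy)phenyl on this saturated chain carbon gives a 26-fold higher number from compound 2 to compound 3 (1.41 log units; beyond the scatter) and so shows that this place responds strongly to what the benzyl group carries, something the earlier step could not show, since both of its compounds hold a carboxylic acid. The acid is still not essential for an effect in this series, as compound 3 has none and gives 155 nM in the same read-out, so a neutral hydroxyethoxy chain can stand here at a clear cost in the concentration needed. No measurement at hand explains the size of this step.

The step swaps the acid for the hydroxyethoxy chain and also moves the substituent from the 3 to the 4 place on the benzyl group, so the two changes cannot be told apart from these compounds. A 4-carboxybenzyl or a 3-(2-hydroxyethoxy)benzyl group would separate them, and an amine or a longer chain ending in a hydroxyl group would show how far this place tolerates other ends.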